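The source may report more compounds than this note shows. Statements on the series, on what has been measured and on what is new or still open speak of the compounds shown alone.

Measured in a functional assay on SW-620 cells (Homo sapiens) for antiproliferative activity, read by CCK-8 assay and cell counting, with a stated time of 72 h; on this read-out higher numbers stand for weaker inhibition and lower numbers for stronger inhibition:
- Compound 1 (`O=C(Nc1ccccc1OC(=O)c1ccc(CCl)cc1)c1ccc(CCl)cc1`): 800 nM
- Compound 2 (`O=C(Nc1ccccc1NC(=O)c1ccc(CO[N+](=O)[O-])cc1)c1ccc(CO[N+](=O)[O-])cc1`): > 100000 nM (a limit)
- Compound 3 (`O=C(Nc1ccccc1)c1ccc(CO[N+](=O)[O-])cc1`): 800 nM

The reading for compound 2 is a limit of the assay and not a number. Compound 3 (800 nM) stands level with compound 1 (800 nM), within the scatter of this assay.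

Compound 4 (`CCc1ccc(C(=O)Nc2ccccc2)cc1`) keeps the core of compound 3 but has methyl in place of nitrooxy on a saturated chain carbon bound to an aromatic carbon, so (nitrooxy)methyl becomes ethyl. Among the compounds with values here, no measured pair isolates this change, so the expectation is a judgement. A large step towards weaker inhibition is expected (a 38-fold higher number from compound 3 to compound 4 (1.57 log units; beyond the scatter)). The estimated value for compound 4 is 30000 nM, within an expected range from 5000 nM to 100000 nM.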

Compound 4, half-maximal inhibitory concentration: > 100000 nM
Compound 4: only a limit was reported; the forecaster's own chance of this, stated with the estimate: 35%; at least 3.3-fold (0.52 log units) between middle value and limit.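

In this assay compound 4 gives > 100000 nM, which is a limit of the assay and not a number. Methyl in place of nitrooxy on a saturated chain carbon bound to an aromatic carbon gives an at least 120-fold higher number from compound 3 to compound 4 (2.09 log units; beyond the scatter), the first comparison here that isolates one change and shows that inhibition depends on the group held at this place. The true size of the step stays unfixed: the limit of > 100000 nM in this assay, at which 2 of the 4 values shown sit.

The compounds shown leave open whether a hydroxymethyl or an aminomethyl group in place of (nitrooxy)methyl would keep the inhibition seen for compound 3.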